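The compounds below may be only part of what the source reports. "The series", "measured", "known", "first", "only" and "open" are said of these compounds alone.

Working notes on the series

Compound 1 `COc1ccc(-n2ccc(=O)c(C(=O)Nc3ccc(Oc4ccnc5[nH]ccc45)c(F)c3)n2)cc1` carries a methoxy on the outer phenyl ring; in a functional assay on MCF7 cells (Homo sapiens) for cytotoxicity, read by MTT assay, with a stated time of 72 h (on this read-out higher numbers stand for weaker inhibition and lower numbers for stronger inhibition), compound 1 gives 55400 nM. Compound 2 `O=C(Nc1ccc(Oc2ccnc3[nH]ccc23)c(F)c1)c1nn(-c2ccc(Br)cc2)ccc1=O` differs from it by one change, (bromo in place of methoxy on an aromatic carbon), and in this assay compound 2 gives 11600 nM. The step is a 4.8-fold lower number from compound 1 to compound 2 (0.68 log units; beyond the scatter).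

Compound 3 `COc1ccc(-n2ccc(=O)c(C(=O)Nc3ccc(Oc4ccnc5c4ccn5C)cc3)n2)cc1` sits on a different core; how the two cores differ is not broken down here. In this assay compound 3 gives > 60000 nM, which is a limit of the assay and not a number. That limit is the limit of > 60000 nM in this assay, at which 1 of the 3 values shown sits.

Compound 4 `Cn1ccc2c(Oc3ccc(NC(=O)c4nn(-c5ccc(Br)cc5)ccc4=O)cc3)ccnc21` is not yet measured. It differs from compound 3 by bromo in place of methoxy on an aromatic carbon, the same change already measured from compound 1 to compound 2, at a place described in the same words.

Expectation for this assay: the step from compound 3 to compound 4 is expected to be an at least 2.4-fold lower number from compound 3 to compound 4 (0.38 log units; beyond the scatter), beside the measured 4.8-fold lower number from compound 1 to compound 2 (0.68 log units; beyond the scatter), on the grounds that the same change on the core of compound 1 gave that step, while compound 3 offers only a limit as a starting point, so the estimate carries added uncertainty. Compound 4 is estimated at 25000 nM, within a range from 8000 nM to 60000 nM, with a real chance that only a limit is reported.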

Compound 4, half-maximal inhibitory concentration: 16300 nM
Compound 4: middle estimate off by 1.5-fold (0.19 log units), on the high side; the measured number falls inside the stated range.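

Replacing methoxy with bromo, read as 4-methoxyphenyl to 4-bromophenyl, gives a lower number on the second core as well, in this assay, with an at least 3.6-fold lower number from compound 3 to compound 4 (0.56 log units; beyond the scatter). The direction therefore carries over from one core to the other, but the comparison of size remains unsettled, and the two cores shown are too few to support a general rule for the series: the same change on two cores in this assay, a 4.8-fold lower number (0.68 log units; beyond the scatter) from compound 1 to compound 2 and an at least 3.6-fold lower number (0.56 log units; beyond the scatter) from compound 3 to compound 4; the limit leaves it open whether they differ. Going by these compounds, the value of compound 3 is a limit of the assay and not a number, so the full size of the step on this core remains unknown: the limit of > 60000 nM in this assay, at which 1 of the 4 values shown sits.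

The compounds shown leave open whether the same step would appear on a third core, and whether the outer phenyl ring would accept groups other than methoxy and bromo, such as an amine, a carboxylic acid or a longer chain. The two cores also differ in more than one place, so the contribution of each difference between them to the values in this assay cannot be read from these compounds.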